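The source may hold more compounds than are shown below. What is called first, only, known or untested is meant among the compounds shown, and "the series" means these compounds.

Within a functional assay on MKN-45 cells (Homo sapiens) for cytotoxicity, read by MTT assay, with a stated time of 72 h (on this read-out higher numbers stand for weaker inhibition and lower numbers for stronger inhibition), compound 3 `COc1ccc(-n2nc(C(=O)Nc3ccc(Oc4ccncc4-c4cccnc4)c(F)c3)c3ccccc3c2=O)cc1` gives 740 nM, the lowest of the three numbers measured, and its separation from the other two lies beyond the scatter. Compound 2 `COc1ccc(-n2nc(C(=O)Nc3ccc(Oc4ccncc4-c4cccnc4)c(F)c3)c(=O)n(C)c2=O)c(OC)c1` gives 2820 nM, and compound 1 `Cn1c(=O)c(C(=O)Nc2ccc(Oc3ccncc3-c3cccnc3)c(F)c2)nn(-c2c(Cl)cccc2Cl)c1=O` gives 3930 nM. Going by the values given here, the one measured single-point step, a 1.4-fold lower number from compound 1 to compound 2 (0.14 log units; within the scatter), changes the group on the aromatic nitrogen, not the position that is altered next, and it is within the scatter; the larger gap from compound 2 to compound 3 involves a change of the core, so no measured step bears directly on the present change. Compound 4 `O=C(Nc1ccc(Oc2ccncc2-c2cccnc2)c(F)c1)c1nn(-c2ccccc2)c(=O)c2ccccc12` differs from compound 3 by hydrogen in place of methoxy on an aromatic carbon. Because a 1.4-fold lower number from compound 1 to compound 2 (0.14 log units; within the scatter) shows a wider substituent change elsewhere in the series passing within the scatter, the loss of one methoxy is expected to move this assay little, if at all, with any drift expected toward a somewhat higher number. The expected step is a 1.4-fold higher number from compound 3 to compound 4 (0.13 log units; within the scatter). Compound 4 is therefore estimated at 1000 nM, with a range from 400 nM to 2500 nM.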

Compound 4, half-maximal inhibitory concentration: 90 nM
Compound 4: middle estimate off by 11-fold (1.05 log units), on the high side; measured number outside the range, below it.
By their numbers in this assay, from the lowest: compound 4; then compound 3; then compounds 2 and 1 (each within the scatter of the next).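

In this assay, going from 4-methoxyphenyl to phenyl gives an 8.2-fold lower number from compound 3 to compound 4 (0.91 log units; beyond the scatter), so this place on the aromatic ring, para to a large group, responds clearly to the loss of the methoxy, and the shift is toward stronger inhibition. The earlier step on the aromatic nitrogen, a 1.4-fold lower number from compound 1 to compound 2 (0.14 log units; within the scatter), stayed within the scatter on a different core, and that quiet result does not carry over to the core shared by compound 3 and compound 4. Nothing measured in the series accounts for the size of this step.

Still open, as far as these compounds go, is whether fluorine, a hydroxyl, an amine or a carboxylic acid at the same place would keep the number near that of compound 4 at 90 nM or lose it. Also open, from the compounds shown here alone, is whether the same change would act alike on the core of compound 1.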